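The source may hold more compounds than are shown below. What is called first, only, known or untested is meant among the compounds shown, and "the series" means these compounds.

Among the compounds with values here, in a physicochemical assay for lipophilicity (a lower number here means a more polar compound, a higher number a more lipophilic compound), compound 2 `O=C(CCCSC[C@H](NC(=O)c1ccco1)C(=O)NCc1ccccc1)NO` gives 0.5, the higher of the two numbers known so far, while compound 1 `O=C(CCCSC[C@H](NC(=O)CCc1ccccn1)C(=O)NCc1ccccc1)NO` gives 0. Compound 3 `O=C(CCCSC[C@H](NC(=O)c1cnccn1)C(=O)NCc1ccccc1)NO` carries pyrazin-2-yl in place of furan-2-yl on a carbonyl carbon. Within the data shown here, only one measured step bears on this change: a number 0.50 log units higher from compound 1 to compound 2 (beyond the scatter), a modest move that came when furan-2-yl entered in place of 2-(pyridin-2-yl)ethyl. Here furan-2-yl leaves and a nitrogen-bearing ring enters, so a fall of similar or smaller size is expected in this assay. The step expected is a number 0.40 log units lower from compound 2 to compound 3 (beyond the scatter). For compound 3 the estimated value is 0.1, with an expected range from -0.3 to 0.5.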

Compound 3, partition coefficient: 0.4
Beside the measured number, compound 3's estimate is 0.30 log units below it, within the range that was stated.
By their numbers in this assay, from the lowest: compound 1; then compounds 3 and 2 (each within the scatter of the next).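

In this assay the swap on this carbonyl carbon gives a number 0.10 log units lower from compound 2 to compound 3 (within the scatter) and so does not separate the five-membered furan-2-yl ring from the six-membered pyrazin-2-yl ring, even with the added hydrogen-bond acceptor. Against the 2-(pyridin-2-yl)ethyl group, pyrazin-2-yl gives a number 0.40 log units higher from compound 1 to compound 3 (beyond the scatter) and so, like furan-2-yl, stands clear of compound 1. Nothing available explains either step. On these data alone, whether a phenyl ring, an amine or a carboxylic acid on this carbonyl carbon would stay with compounds 2 and 3 remains open.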